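A few compounds are considered here, and "the series" means these few. Any claim that something is new, unique, unknown or untested is made for them only; others in the source may bear on it.

Measured: compound 1 `CCCS(=O)(=O)Nc1cccc2c1CCC2c1ncc[nH]1` and compound 2 `c1cc(-c2ncco2)c2c(c1)C(c1ncc[nH]1)CC2`. In a functional assay on CHO cells for agonist activity at Alpha-1D adrenergic receptor (Homo sapiens), read by FLIPR and calcium flux (a lower number here means that less compound is needed, a higher number that more compound is needed for the effect), compound 1 gives > 10000 nM, which is a limit of the assay and not a number. In this assay compound 2 gives 1390 nM.

Going by the values given here, compound 2 thus holds the only number measured; the other value shown is a limit. Compound 3 `CCS(=O)(=O)Nc1cccc2c1CCC2c1ncc[nH]1` differs from compound 2 by (ethylsulfonyl)amino in place of 1,3-oxazol-2-yl on an aromatic carbon. Among the compounds with values here, the one measured step that bears on this change is an at least 7.1-fold lower number from compound 1 to compound 2 (0.85 log units; beyond the scatter), a (propylsulfonyl)amino group giving way to the oxazolyl group; compound 3 runs this change backwards with an ethylsulfonyl chain, so the number is expected to rise by a 7.2-fold higher number from compound 2 to compound 3 (0.86 log units; beyond the scatter). Compound 1 sits at the limit of > 10000 nM in this assay, at which 1 of the 2 values shown sits, so a limit is again likely. Compound 3 is expected to give 10000 nM, within 3000 nM to 30000 nM.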

Compound 3, half-maximal effective concentration: > 10000 nM
Compound 3 was reported as a limit; the forecaster's own chance of this, stated with the estimate: 70%; the middle value lies on the limit itself.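

In this assay the (ethylsulfonyl)amino group in place of 1,3-oxazol-2-yl on this aromatic carbon gives an at least 7.1-fold higher number from compound 2 to compound 3 (0.85 log units; beyond the scatter) and so repeats, with a second sulfonyl chain, the gap first seen with the propyl chain. Compound 3 gives > 10000 nM as a limit of the assay and not a number, and the two sulfonyl compounds now share it: the limit of > 10000 nM in this assay, at which 2 of the 3 values shown sit. The step from compound 1 to compound 3 cannot be read, so no chain-length trend can be drawn.

On these data alone, what an amine or a carboxylic acid on this aromatic carbon would give stays open. So does whether a thiazol-2-yl group would match 1,3-oxazol-2-yl.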